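The source may report more compounds than this note shows. Statements on the series, on what has been measured and on what is new or still open speak of the compounds shown alone.

Working notes on the series. Two compounds carry numbers in an ADME assay on microsomes from liver (Homo sapiens) for metabolic stability, read by LC-MS, using NADPH, with stated times of 5 min and 30 min, tested at 1 uM; on this read-out lower numbers stand for slow clearance and higher numbers for fast clearance. Compound 1 `O=C(Nc1ccccc1)c1cnc(NCc2c(F)ccc3c2CCO3)n2cnnc12` in this assay gives 14 mL.min-1.g-1. Compound 2 `Cc1ncccc1-c1cnc(NCc2c(F)ccc3c2CCO3)n2c(=O)[nH]nc12` in this assay gives 36 mL.min-1.g-1. Compound 1 therefore holds the lowest of the two numbers, and its gap to compound 2 lies beyond the usual scatter, so compound 1 is the slower-cleared of the pair on this read-out.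

Compound 3 `O=C1CCCN1c1cnc(NCc2c(F)ccc3c2CCO3)n2cnnc12` differs from compound 1 in one place: 2-oxopyrrolidin-1-yl in place of phenylcarbamoyl on an aromatic carbon. The phenylcarbamoyl group leaves and 2-oxopyrrolidin-1-yl enters, on an aromatic carbon of the six-membered aromatic ring with two nitrogen, para to a large group.

Within the data shown here, no measured pair shows this change, so its size cannot be read from a measured step. The shared core is kept, and compound 1 with 14 mL.min-1.g-1 already sits at the low end of the two numbers. A small step toward slower clearance in this assay, or none beyond the scatter, is expected. The expected step is a 1.4-fold lower number from compound 1 to compound 3 (0.15 log units; within the scatter). Compound 3 is estimated at 10 mL.min-1.g-1 in this assay, in the range 5 mL.min-1.g-1 to 22 mL.min-1.g-1.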

Compound 3, intrinsic clearance in microsomes: < 3 mL.min-1.g-1
Compound 3 gave a limit, no number; the forecaster's own chance of this, stated with the estimate: 10%; at least 3.3-fold (0.52 log units) between middle value and limit.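

This position, on an aromatic carbon of a six-membered aromatic ring with 2 nitrogen and para to a large group, now has a measured single-place step in this assay: with the shared core kept, 2-oxopyrrolidin-1-yl in place of phenylcarbamoyl gives an at least 4.6-fold lower number from compound 1 to compound 3 (0.66 log units; beyond the scatter). Compound 3 reads as a limit of the assay, not a number: the limit of < 3 mL.min-1.g-1 in this assay, at which 1 of the 3 values shown sits. The step therefore gives only a smallest size, and compound 1, the lowest of the earlier numbers, no longer marks the low end of clearance on this read-out.

The compounds shown leave open which part of the change carries the step: the leaving aromatic ring of carbon only, the leaving hydrogen-bond donor, or the smaller group as a whole, and an open-chain acetamido group or a six-membered piperidin-2-one ring at this position would begin to separate these. Going by these compounds, whether the same replacement gives a step of this kind on the core of compound 2 also stays open.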